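The compounds below may be only part of what the source reports. "The series", "measured", "known", "first", "only" and "open" are said of these compounds alone.

Measured compounds in an ADME assay on HUVEC cells (Homo sapiens) for antiproliferative activity, read by MTT assay, with a stated time of 48 h; a higher number here means a weaker inhibitor, a lower number a stronger inhibitor:
compound 1 `Cc1ccccc1-n1nncc1CN1C(=O)C2(C(C#N)=C(N)Oc3c2c2nc4ccccc4nc2c2ccccc32)c2ccccc21` gives > 50000 nM, which is a limit of the assay and not a number.
compound 2 `N#CC1=C(N)Oc2c(c3nc4ccccc4nc3c3ccccc23)C12C(=O)N(Cc1cnnn1-c1ccccc1Cl)c1ccccc12` gives > 50000 nM, again a limit.
compound 3 `CCc1ccccc1-n1nncc1CN1C(=O)C2(C(C#N)=C(N)Oc3c(N)cc4nc5ccccc5nc4c32)c2ccccc21` gives > 50000 nM, again a limit.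

Among the compounds with values here, compound 3 therefore stands where every value in this assay stands, at the limit described by the limit of > 50000 nM in this assay, at which 3 of the 3 values shown sit; no compound in the set has yet returned a number. Within the data shown here, the only measured step, a step that the two limits leave unreadable from compound 1 to compound 2, runs between two limits and its size cannot be read.

Compound 4 `Cc1ccc(-n2nncc2CN2C(=O)C3(C(C#N)=C(N)Oc4c(N)cc5nc6ccccc6nc5c43)c3ccccc32)cc1C` differs from compound 3 by 3,4-dimethylphenyl in place of 2-ethylphenyl on an aromatic nitrogen. Among the measured compounds shown here, the one measured step is itself a change within the group on that aromatic nitrogen, and both of its ends are limits, so no step of readable size bears on this change. With nothing to set a direction, the step from compound 3 to compound 4 is expected to be a step that the limit leaves unreadable from compound 3 to compound 4, with no movement beyond the scatter. Compound 4 is estimated at 60000 nM, within 20000 nM to 200000 nM, and most likely the assay will again report only a limit.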

Compound 4, half-maximal inhibitory concentration: > 50000 nM
Compound 4 gave a limit, no number; the forecaster's own chance of this, stated with the estimate: 85%; the middle value is on the limit's open side.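

Compound 4 returns > 50000 nM, a limit and not a number, so the step from compound 3 to compound 4 cannot be read. The compounds shown leave open whether any change to the shared core or to the group on the aromatic nitrogen would give a readable value, with every result so far at one limit: the limit of > 50000 nM in this assay, at which 4 of the 4 values shown sit.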